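Swapping Bromine for Chlorine on the Fused Ring

The source may hold more compounds than are shown below. What is called first, only, known or untested is meant among the compounds shown, and "the series" means these compounds.

Three compounds share one core and differ in a single substituent. In a functional assay on MCF7 cells (Homo sapiens) for antiproliferative activity, read by sulforhodamine B assay, with a stated time of 72 h, tested at 30 uM (on this read-out higher numbers stand for a weaker effect at the one concentration tested and lower numbers for a stronger effect), compound 1 `COC(=O)C1=C(N)Oc2ccc(Br)cc2C1CC(=O)c1ccc(Br)cc1` gives 34.8%. Compound 2 `COC(=O)C1=C(N)Oc2ccc(Br)cc2C1CC(=O)c1ccccc1` gives 41.3%. Compound 3 `COC(=O)C1=C(N)Oc2ccc(Br)cc2C1CC(=O)c1ccc(Cl)cc1` gives 32.4%. Compound 2 shows the largest of the three numbers, yet a number 6.5 percentage points higher from compound 1 to compound 2 (within the scatter) and a number 8.9 percentage points lower from compound 2 to compound 3 (within the scatter) both lie within the scatter. Compound 4 `COC(=O)C1=C(N)Oc2ccc(Cl)cc2C1CC(=O)c1ccccc1` differs from compound 2 by chloro in place of bromo on an aromatic carbon. The closest comparison is a number 2.4 percentage points lower from compound 1 to compound 3 (within the scatter), the same kind of swap made elsewhere on the molecule, which changed nothing beyond the scatter. A similar outcome is expected here, so the estimated step is a number 1.3 percentage points lower from compound 2 to compound 4 (within the scatter). Compound 4 is therefore expected to give about 40%, within a range from 28% to 52%.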

Compound 4, a percentage reported as activity, at one concentration (the size of the read-out at that concentration, not a potency): 44.2%
Compound 4: middle estimate off by 4.2 percentage points, on the low side, and the stated range covers the measured number.
By their numbers in this assay, from the lowest: compounds 3, 1, 2 and 4 (each within the scatter of the next, the first and the last beyond it).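

In this assay, chloro in place of bromo on the aromatic carbon of the fused system gives a number 2.9 percentage points higher from compound 2 to compound 4 (within the scatter), so at this position the two halogens cannot be told apart. The swap now reads alike at two places on the molecule, and the two steps do not differ beyond what repeated measurements would allow: the same change on two cores in this assay, a number 2.4 percentage points lower (within the scatter) from compound 1 to compound 3 and a number 2.9 percentage points higher (within the scatter) from compound 2 to compound 4, 5.3 percentage points apart, within the scatter of two such steps

Going by these compounds, whether an amine, a methoxy group or a carboxylic acid at this position would shift the number beyond the scatter remains open. A single concentration also leaves open whether these compounds would show a stronger or weaker effect at any other concentration.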